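This account rests on a few compounds, and the source may have more. Where it says the series, first, only, none or still open, it means among the compounds named here.

Measured compounds:
compound 1, `CC(=O)Nc1ccc(/C=N/Nc2nc(N)c3ncn([C@@H]4O[C@H](CO)[C@@H](O)[C@H]4O)c3n2)cc1`, giving 0% in an assay on CHO-K1 cells for displacement of a labelled ligand from adenosine receptor A1 (Homo sapiens), read by scintillation counting, with a stated time of 60 min, tested at 1 uM; on this read-out lower numbers stand for less inhibition and higher numbers for more inhibition at the one concentration tested (going by the name of the read-out)
compound 2, `Nc1nc(N/N=C/c2ccc(Cl)c(C(F)(F)F)c2)nc2c1ncn2[C@@H]1O[C@H](CO)[C@@H](O)[C@H]1O`, giving 11% in this assay

Among the measured compounds shown here, compound 2 stands highest of these two numbers; its nearest neighbour is compound 1, and the only measured step, a number 11 percentage points higher from compound 1 to compound 2 (beyond the scatter), is modest. Compound 3, `Nc1nc(N/N=C/c2ccc(-n3ccnc3)cc2)nc2c1ncn2[C@@H]1O[C@H](CO)[C@@H](O)[C@H]1O`, differs from compound 2 by 4-(1H-imidazol-1-yl)phenyl in place of 4-chloro-3-(trifluoromethyl)phenyl on a carbon with a double bond to nitrogen. For the measured compounds named here, no measured step exchanges the aryl group for this imidazolylphenyl; the single step shows that swapping the aryl group moves the number only modestly. Compound 3 is therefore expected to show no step beyond the scatter, a number 5 percentage points lower from compound 2 to compound 3 (within the scatter). The estimated value of compound 3 in this assay is 6%, ranging from 0% to 20%.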

Compound 3, a percentage reported as inhibition, at one concentration (the size of the read-out at that concentration, not a potency): 0%
Beside the measured number, compound 3's estimate is 6 percentage points above it; low and high end bracket the measured number.
By their numbers in this assay, from the lowest: compounds 1 and 3 (each within the scatter of the next); then compound 2.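

In this assay, 4-(1H-imidazol-1-yl)phenyl in place of 4-chloro-3-(trifluoromethyl)phenyl on a carbon with a double bond to nitrogen gives a number 11 percentage points lower from compound 2 to compound 3 (beyond the scatter) and so adds a second step at this position. On an aromatic carbon, 1H-imidazol-1-yl in place of acetamido gives no change at the digits printed from compound 1 to compound 3 (within the scatter) and so shows two different groups reading alike, with only compound 2 standing apart. Nothing available explains these numbers.

On these data alone, it remains open whether the chloro or the trifluoromethyl group accounts for the higher number of compound 2. As far as these compounds go, how an amine or a carboxylic acid on the phenyl ring would read also remains open.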